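Ring Size at the Aromatic Carbon: Seven to Eight

The compounds below may be only part of what the source reports. "The series", "measured", "known", "first", "only" and "open" are said of these compounds alone.

Compound 1, `CC(C(=O)NCc1ccc(C(F)(F)F)cc1N1CCCC1)c1ccc(NS(C)(=O)=O)c(F)c1`, in an assay on CHO cells for antagonist activity at transient receptor potential cation channel subfamily V member 1 (Homo sapiens), read by FLIPR; on this read-out lower numbers stand for stronger inhibition and higher numbers for weaker inhibition: 2.3 nM
Compound 2, `CC(C(=O)NCc1ccc(C(F)(F)F)cc1N1CCCCCC1)c1ccc(NS(C)(=O)=O)c(F)c1`, in this assay: 1.6 nM
Compound 3, `CC(C(=O)NCc1ccc(C(F)(F)F)cc1N1CCCCCCC1)c1ccc(NS(C)(=O)=O)c(F)c1`, not yet measured

Within the data shown here, the two compounds measured so far share one core and differ only in the saturated ring attached to the aromatic carbon. Among the measured compounds shown here, the step of a 1.4-fold lower number from compound 1 to compound 2 (0.16 log units; within the scatter) is the only measured comparison, and it lies within the usual scatter, so the two numbers cannot be told apart with confidence. Compound 2 holds the lower of the two numbers, but only by a margin that repeated measurements would blur.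

Compound 3 continues in the same direction: a group of 8 heavy atoms (7 carbon, 1 nitrogen; one eight-membered non-aromatic ring with 1 hetero atom) in place of a group of 7 heavy atoms (6 carbon, 1 nitrogen; one seven-membered non-aromatic ring with 1 hetero atom), on an aromatic carbon. For the measured compounds named here, the one step that bears on this change, the step from compound 1 to compound 2, enlarged the ring by one atom and gave no shift beyond the scatter. With a single such comparison, a further enlargement offers no ground for expecting a real shift in either direction.

Compound 3 is therefore expected to land near compound 2, at an estimated 2 nM, within a range from 0.7 nM to 6 nM. The expected step of a 1.3-fold higher number from compound 2 to compound 3 (0.10 log units; within the scatter) amounts to no change beyond the scatter.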

Compound 3, inhibition constant: 2.8 nM
Estimate against measurement, compound 3: 1.4-fold (0.15 log units) below; measured number inside the range.
By their numbers in this assay, from the lowest: compounds 2, 1 and 3 (each within the scatter of the next).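

With compound 3 added, three ring sizes can be compared at this position on the shared core. In this assay, enlarging the ring further gives a 1.8-fold higher number from compound 2 to compound 3 (0.24 log units; within the scatter), and going from the smallest ring to the largest gives a 1.2-fold higher number from compound 1 to compound 3 (0.09 log units; within the scatter), so the eight-membered ring cannot be told apart from either smaller ring. Among these three compounds, none goes against a simple reading: this aromatic carbon, ortho to a large group and meta to a trifluoromethyl group, carries a saturated nitrogen ring of any of these sizes with no readable difference, which one earlier step alone could not show. Nothing available explains this flat result.

The compounds shown leave open whether the same holds for a ring with a second hetero atom, such as morpholin-4-yl, or for an open-chain group, such as diethylamino, in place of the ring. They also leave open whether a still larger nitrogen ring, or a methyl group added to the azepan-1-yl ring, would finally move the number beyond the usual scatter.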